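The source may hold more compounds than are shown below. What is called first, only, known or untested is meant among the compounds shown, and "the series" means these compounds.

Compound 1 `O=C(O)COc1ccc(NCc2cccc(Oc3ccccc3)c2)cc1` is tested in a functional assay on CHO cells for agonist activity at Free fatty acid receptor 1 (Homo sapiens), read by a luciferase reporter (on this read-out lower numbers stand for smaller maximal responses and higher numbers for larger maximal responses), where compound 1 gives 84%. That is the lowest of the three values measured: compound 3 `Cc1nc(-c2ccc(C(F)(F)F)cc2)sc1CNc1ccc(CCC(N)=O)cc1` reaches 88%, within the scatter of compound 1, while compound 2 `Cc1nc(-c2ccc(C(F)(F)F)cc2)sc1CNc1ccc(OCC(=O)O)cc1` reaches 100%, beyond it. Compound 4 `O=C(CCc1ccc(NCc2cccc(Oc3ccccc3)c2)cc1)N1CCCC1` differs from compound 1 in one place: 2-((pyrrolidin-1-yl)carbonyl)ethyl in place of carboxymethoxy on an aromatic carbon. Among the compounds with values here, the only measured step that resembles this change is a number 12 percentage points lower from compound 2 to compound 3 (beyond the scatter), where carboxymethoxy gave way to 2-carbamoylethyl, a change that parallels the present one. A modest decrease beyond the scatter is therefore expected in this assay, although a single step is a thin basis. Compound 4 is expected to reach 72%, between 52% and 92%. That expectation amounts to a number 12 percentage points lower from compound 1 to compound 4 (beyond the scatter).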

Compound 4, largest response reached (reported as percent of maximum), in percent of the reference or control that the assay uses: 46%
For compound 4 the middle estimate is 26 percentage points above the measured one; the measured number lies below the stated range.
By their numbers in this assay, from the lowest: compound 4; then compounds 1 and 3 (each within the scatter of the next); then compound 2.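

In this assay, the core of compound 1 does not tolerate this exchange well: putting 2-((pyrrolidin-1-yl)carbonyl)ethyl in place of carboxymethoxy gives a large change, with a number 38 percentage points lower from compound 1 to compound 4 (beyond the scatter). The earlier exchange on another core was only modest, with a number 12 percentage points lower from compound 2 to compound 3 (beyond the scatter), so leaving carboxymethoxy behind does not cost the same in both pairs. Nothing measured here explains the size of this drop. Going by these compounds, those two pairs differ in both core and entering group, so the share of each remains open. A 2-carboxyethyl group in this place would show how much depends on the chain and how much on its carboxylic acid end.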